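The compounds below may be only part of what the source reports. "The series", "measured", "known", "first", "only" and "open" are said of these compounds alone.

For the measured compounds named here, compound 1 `CNC(=O)CCc1ccc(NC(=O)Nc2ccc(Cl)c(C(F)(F)F)c2)cc1` is the only member of this set with a measured number: in a functional assay on HepG2 cells (Homo sapiens) for inhibition, read by MTT assay, with a stated time of 120 h (a higher number here means a weaker inhibitor, a lower number a stronger inhibitor), compound 1 gives 21000 nM. Compound 3 `CNC(=O)/C=C(\C)c1ccc(NC(=O)Nc2ccc(Cl)c(C(F)(F)F)c2)cc1` shares its core but carries a different chain; how they differ is 2-(methylcarbamoyl)ethyl in place of 1-methyl-2-(methylcarbamoyl)ethenyl on an aromatic carbon. In this assay compound 3 reaches only the limit of the measurement, > 50000 nM. That gives an at least 2.3-fold higher number from compound 1 to compound 3 (0.37 log units; beyond the scatter). Compound 2 `C/C(=C\C(=O)N1CC(C)OC(C)C1)c1ccc(NC(=O)Nc2ccc(Cl)c(C(F)(F)F)c2)cc1` is built from compound 3 by 2,6-dimethylmorpholin-4-yl in place of methylamino on a carbonyl carbon. Compound 2 also sits at a limit in this assay, > 50000 nM. The step that the two limits leave unreadable from compound 3 to compound 2 therefore cannot be sized, because the limit of > 50000 nM in this assay, at which 2 of the 3 values shown sit, hides both ends of it.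

Compound 4 `CC1CN(C(=O)CCc2ccc(NC(=O)Nc3ccc(Cl)c(C(F)(F)F)c3)cc2)CC(C)O1` is not yet measured. It relates to compound 1 by 2,6-dimethylmorpholin-4-yl in place of methylamino on a carbonyl carbon, the same kind of change as that from compound 3 to compound 2, though here the carbonyl carbon's other neighbour is a saturated chain carbon rather than a double-bonded chain carbon. The earlier instance gives no readable size, so the expectation rests on compound 1 alone at 21000 nM. Compound 4 is expected to show a 1.7-fold higher number from compound 1 to compound 4 (0.22 log units; within the scatter), a weaker inhibitor, with an estimated 35000 nM between 12000 nM and 100000 nM.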

Compound 4, half-maximal inhibitory concentration: > 50000 nM
Compound 4 was reported as a limit; the forecaster's own chance of this, stated with the estimate: 35%; at least 1.4-fold (0.15 log units) between middle value and limit.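

In this assay compound 4 gives > 50000 nM, which is a limit of the assay and not a number. On the core of compound 1, where the carbonyl carbon carries a saturated chain carbon, putting 2,6-dimethylmorpholin-4-yl in place of methylamino gives an at least 2.3-fold higher number from compound 1 to compound 4 (0.37 log units; beyond the scatter), so the direction of the change on this core can be read, but its full size cannot. The same change on the core of compound 3 cannot be read, so the series does not show whether its effect carries from one core to the other, because both ends of that step are hidden: the limit of > 50000 nM in this assay, at which 3 of the 4 values shown sit.

Compound 1, at 21000 nM, remains the only compound here with a number, so the shown compounds offer just one measured reference point. From the compounds shown here alone, it remains open whether a smaller amine such as dimethylamino or an unsubstituted morpholin-4-yl on the same carbonyl carbon would give a number rather than a limit, and the same question stands for a carboxylic acid in place of the amide.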